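Fluoro for chloro on the amide-bound ring

The source may report more compounds than this note shows. Statements on the series, on what has been measured and on what is new or still open speak of the compounds shown alone.

Measured so far in a functional assay on MDA-MB-231 cells (Homo sapiens) for inhibition, read by MTT assay, with a stated time of 72 h; a higher number here means a weaker inhibitor, a lower number a stronger inhibitor: compound 1 `O=C(CSc1nc(Nc2ccccc2)c2ccccc2n1)Nc1ccccc1F` gives > 50000 nM, which is a limit of the assay. Compound 2 `O=C(CSc1nc(Nc2ccccc2)c2ccccc2n1)Nc1ccccc1Cl` gives 24400 nM. Compound 3 `O=C(CSc1nc(Nc2ccccc2)c2ccccc2n1)Nc1ccc(Cl)c(Cl)c1` gives 14500 nM.

Compound 3 differs from compound 2 by 3,4-dichlorophenyl in place of 2-chlorophenyl on an amide-type nitrogen; the step is a 1.7-fold lower number from compound 2 to compound 3 (0.23 log units; within the scatter). Compound 1 differs from compound 2 by fluoro in place of chloro on an aromatic carbon; the step is an at least 2.0-fold higher number from compound 2 to compound 1 (0.31 log units; beyond the scatter), resting on (the limit of > 50000 nM in this assay, at which 1 of the 3 values shown sits). Compound 4 `O=C(CSc1nc(Nc2ccccc2)c2ccccc2n1)Nc1ccc(F)c(Cl)c1` is not yet measured; it differs from compound 3 by fluoro in place of chloro on an aromatic carbon. This is the same kind of change as from compound 2 to compound 1, but the place differs: there the fluoro sits ortho to a large group, here ortho to a chloro group and para to a large group. The step from compound 3 to compound 4 is expected to be a 2.1-fold higher number from compound 3 to compound 4 (0.32 log units; beyond the scatter), a weakening of similar size to an at least 2.0-fold higher number from compound 2 to compound 1 (0.31 log units; beyond the scatter). Compound 4 is therefore estimated at 30000 nM in this assay, between 15000 nM and 70000 nM.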

Compound 4, half-maximal inhibitory concentration: 21600 nM
Compound 4: middle estimate off by 1.4-fold (0.14 log units), on the high side; the measured number falls inside the stated range.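

In this assay, fluoro in place of chloro on the 3,4-dichlorophenyl ring gives a 1.5-fold higher number from compound 3 to compound 4 (0.17 log units; within the scatter), so the change seen on the 2-chlorophenyl ring is not confirmed beyond the scatter here, and whether the two steps differ cannot be settled: the same change on two cores in this assay, an at least 2.0-fold higher number (0.31 log units; beyond the scatter) from compound 2 to compound 1 and a 1.5-fold higher number (0.17 log units; within the scatter) from compound 3 to compound 4; the limit leaves it open whether they differ

Compound 1 gives > 50000 nM, which is a limit, and every step involving it rests on that: the limit of > 50000 nM in this assay, at which 1 of the 4 values shown sits.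

The remaining steps read a 1.1-fold lower number from compound 2 to compound 4 (0.05 log units; within the scatter) and an at least 2.3-fold lower number from compound 1 to compound 4 (0.36 log units; beyond the scatter), the second resting on that limit, and together these compounds give no rule for this change on other cores.

On these data alone, what a methoxy group, a nitrile or a carboxylic acid would give in place of these halogens stays open, as does any change to the phenyl group on the amine nitrogen of the shared core.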